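Pyrazole carboxamides on the shared thiophene core: ring swap check

The source may hold more compounds than are shown below. What is called first, only, known or untested is meant among the compounds shown, and "the series" means these compounds.

The three measured compounds share one core and differ only in the ring on the carbonyl carbon. Compound 1 `CC1(C)Cc2c(sc(NC(=O)c3cccnc3O)c2C(N)=O)C(C)(C)O1` gives 190 nM in an assay on cells for positive allosteric modulation of Cystic fibrosis transmembrane conductance regulator variant F508del (Homo sapiens), with stated times of 10 min and 7 s, in the presence of a further agent that is not named here; a higher number here means that more compound is needed for the effect, a lower number that less compound is needed. Compound 2 `CC1(C)Cc2c(sc(NC(=O)c3cn[nH]c3)c2C(N)=O)C(C)(C)O1` gives 125 nM in this assay, and a 1.5-fold lower number from compound 1 to compound 2 (0.18 log units; within the scatter). Compound 3 `CC1(C)Cc2c(sc(NC(=O)c3ccn[nH]3)c2C(N)=O)C(C)(C)O1` gives 3 nM in this assay, the lowest number of the three, since a 63-fold lower number from compound 1 to compound 3 (1.80 log units; beyond the scatter) and a 42-fold lower number from compound 2 to compound 3 (1.62 log units; beyond the scatter); compound 3 is thus the most potent compound measured here.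

Compound 4 `CC1(C)Cc2c(sc(NC(=O)C3CCNC3=O)c2C(N)=O)C(C)(C)O1` carries the change (2-oxopyrrolidin-3-yl in place of 1H-pyrazol-5-yl on a carbonyl carbon). For the measured compounds named here, the steps that bear on it are those into compound 3: the two measured ring exchanges on this carbonyl carbon were both large, and the 1H-pyrazol-5-yl of compound 3 stands far apart from the other two rings. Nothing measured involves a five-membered non-aromatic ring at this position, so the direct information is lacking. Given that the two other rings tried here sit at the numbers of compound 1 and compound 2, a large step to a higher number is expected for compound 4, with wide uncertainty. Compound 4 is therefore estimated at 150 nM in this assay, with a range of 25 nM to 900 nM. The estimated step is a 50-fold higher number from compound 3 to compound 4 (1.70 log units; beyond the scatter).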

Compound 4, half-maximal effective concentration: 101 nM
Beside the measured number, compound 4's estimate is 1.5-fold (0.17 log units) above it, and the stated range covers the measured number.
By their numbers in this assay, from the lowest: compound 3; then compounds 4, 2 and 1 (each within the scatter of the next).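

Working note: replacing 1H-pyrazol-5-yl with the non-aromatic 2-oxopyrrolidin-3-yl on this carbonyl carbon gives a 34-fold higher number from compound 3 to compound 4 (1.53 log units; beyond the scatter) in this assay, so this first non-aromatic ring does not retain the low number of compound 3. For the compounds shown here, the other two comparisons, a 1.2-fold lower number from compound 2 to compound 4 (0.09 log units; within the scatter) and a 1.9-fold lower number from compound 1 to compound 4 (0.27 log units; within the scatter), place the new ring within the scatter of 1H-pyrazol-4-yl and 2-hydroxypyridin-3-yl, which leaves 1H-pyrazol-5-yl as the only one of the four rings standing apart, while an aromatic ring as such is not enough, as compound 1 and compound 2 show, and neither is a matching count of hydrogen-bond donors and acceptors, as 1H-pyrazol-5-yl and 2-oxopyrrolidin-3-yl have the same counts. No supporting data are available to explain this difference between the rings.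

Open, going by these compounds, is whether the low number of compound 3 is unique to 1H-pyrazol-5-yl or also appears with an imidazole or triazole ring on this carbonyl carbon. Also open, on these data alone, are how an amine or a carboxylic acid on the ring would read here, and whether the two mirror-image forms of 2-oxopyrrolidin-3-yl give the same number.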